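This account rests on a few compounds, and the source may have more. Where it says the series, first, only, none or still open, it means among the compounds named here.

Among the measured compounds shown here, compound 3 `CC(C)c1sc(C2CCCC2)c(-c2ccc(F)cc2)c1/C=C/[C@@H](O)C[C@@H](O)CC(=O)O` gives 570 nM in an assay on microsomes for inhibition of 3-hydroxy-3-methylglutaryl-coenzyme A reductase (Rattus norvegicus) (a lower number here means a stronger inhibitor, a higher number a weaker inhibitor), the highest of the three numbers so far; compound 2 `CC(C)c1sc(C(C)C)c(-c2ccc(F)cc2)c1/C=C/[C@@H](O)C[C@@H](O)CC(=O)O` gives 26 nM and compound 1 `CC(C)c1sc(-c2ccccc2)c(-c2ccc(F)cc2)c1/C=C/[C@@H](O)C[C@@H](O)CC(=O)O` gives 4.4 nM. Compound 4 `CC(C)c1sc(-c2ccc(Cl)cc2)c(-c2ccc(F)cc2)c1/C=C/[C@@H](O)C[C@@H](O)CC(=O)O` differs from compound 3 by 4-chlorophenyl in place of cyclopentyl on an aromatic carbon. The step bearing most on this change is a 130-fold higher number from compound 1 to compound 3 (2.11 log units; beyond the scatter), which the move to compound 4 largely reverses; a 5.9-fold higher number from compound 1 to compound 2 (0.77 log units; beyond the scatter) and a 22-fold higher number from compound 2 to compound 3 (1.34 log units; beyond the scatter) point the same way, phenyl standing at the low end and cyclopentyl at the high end. A large drop in this assay is therefore expected for compound 4, about a 140-fold lower number from compound 3 to compound 4 (2.15 log units; beyond the scatter), putting it near compound 1. The estimate for compound 4 is 4 nM, with a range from 1.5 nM to 15 nM.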

Compound 4, half-maximal inhibitory concentration: 21 nM
Compound 4: middle estimate off by 5.3-fold (0.72 log units), on the low side; the measured number lies above the stated range.
By their numbers in this assay, from the lowest: compound 1; then compounds 4 and 2 (each within the scatter of the next); then compound 3.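

In this assay, the aromatic ring recovers much of the gap left by cyclopentyl (a 27-fold lower number from compound 3 to compound 4 (1.43 log units; beyond the scatter)), but adding chloro to the phenyl ring is not neutral at this position (a 4.8-fold higher number from compound 1 to compound 4 (0.68 log units; beyond the scatter)). 4-Chlorophenyl and isopropyl cannot be separated here (a 1.2-fold lower number from compound 2 to compound 4 (0.09 log units; within the scatter)), so an aromatic ring at this position is not needed to reach this level. No supporting measurement bears on the origin of these differences.

On these data alone, whether the loss belongs to chloro specifically or extends to other groups on that phenyl ring remains open, for instance methoxy or methyl. Also open, as far as these compounds go, is how cyclopropyl or tert-butyl would stand relative to isopropyl and cyclopentyl.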